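Benzyl to furanylmethyl swap: notes on compound 3

This account rests on a few compounds, and the source may have more. Where it says the series, first, only, none or still open, it means among the compounds named here.

compound 1 `CCCSc1nc(N/N=C(\C)c2ccccc2O)c2nnn(Cc3cccc(Cl)c3)c2n1` — 39900 nM
compound 2 `CCCSc1nc(N/N=C(\C)c2ccccc2O)c2nnn(Cc3ccc(Br)cc3)c2n1` — 15600 nM

Two compounds of the series have numbers in a functional assay on MCF7 cells (Homo sapiens) for antiproliferative activity, read by MTT assay, with a stated time of 72 h; a higher number here means a weaker inhibitor, a lower number a stronger inhibitor. Compound 1 gives 39900 nM. Compound 2 gives 15600 nM. For the measured compounds named here, the single measured step is a 2.6-fold lower number from compound 1 to compound 2 (0.41 log units; beyond the scatter), so compound 2 holds the lowest of the two numbers, with compound 1 as its only neighbour at that distance.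

Compound 3 `CCCSc1nc(N/N=C(\C)c2ccccc2O)c2nnn(Cc3ccco3)c2n1` is the next member. Its difference from compound 2 is furan-2-yl in place of 4-bromophenyl on a saturated chain carbon bound to an aromatic nitrogen. Going by the values given here, no measured step concerns this kind of exchange: the one step on record swaps one halophenyl for another at the same place, and its size, given by a 2.6-fold lower number from compound 1 to compound 2 (0.41 log units; beyond the scatter), is modest. That step sets only the scale of what this place has shown so far; it gives no direction for replacing a halophenyl by furan-2-yl.

On that footing, compound 3 is expected to give a somewhat higher number than compound 2, a step of about a 1.8-fold higher number from compound 2 to compound 3 (0.25 log units; within the scatter), likely beyond the scatter but not large. The estimate for compound 3 in this assay is 28000 nM, with a range from 9000 nM to 90000 nM.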

Compound 3, half-maximal inhibitory concentration: 29000 nM
Compound 3: the middle estimate sits 1.0-fold (0.02 log units) below what was measured; the range from low to high includes it.
By their numbers in this assay, from the lowest: compounds 2, 3 and 1 (each within the scatter of the next, the first and the last beyond it).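

With furan-2-yl at this place, on a saturated chain carbon bound to an aromatic nitrogen, the series gains its first member without a halophenyl ring, and this assay gives a 1.9-fold higher number from compound 2 to compound 3 (0.27 log units; within the scatter) and a 1.4-fold lower number from compound 1 to compound 3 (0.14 log units; within the scatter) as the two new steps. Both steps lie within the scatter, although the two halophenyl compounds are separated by a step beyond it, so among these three compounds a halophenyl ring is not needed for a number in this range, and the smaller furan-2-yl ring, which also brings a hydrogen-bond acceptor, cannot be told apart from either halophenyl compound. No supporting measurement bears on this result, so the flat outcome stands without an explanation.

The compounds shown leave open whether the furan oxygen counts at all, which thiophen-2-yl or unsubstituted phenyl at the same place would test, and whether any aromatic ring is needed there, which cyclohexyl or a longer alkyl chain would test. Also open, from the compounds shown here alone, is how this place responds to a group of a different kind, such as an amine or a carboxylic acid carried on the same chain carbon.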